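The source may report more compounds than this note shows. Statements on the series, on what has been measured and on what is new or still open speak of the compounds shown alone.

Of the compounds shown here, three of the shared core have been measured in an assay on Sf9 cells for inhibition of mitogen-activated protein kinase kinase kinase 14 variant S549D (Homo sapiens), with a stated time of 30 min, in the presence of a further agent that is not named here; on this read-out lower numbers stand for stronger inhibition and higher numbers for weaker inhibition. Compound 1 `C#Cc1ccc2ncn(-c3ccnc(N)n3)c2c1` gives 251 nM. Compound 2 `C=CC(=O)NCC#Cc1ccc2ncn(-c3ccnc(N)n3)c2c1` gives 6310 nM and compound 3 `C=Cc1cc(C#Cc2ccc3ncn(-c4ccnc(N)n4)c3c2)ccn1` gives 20000 nM, the highest number of the three, as shown by an 80-fold higher number from compound 1 to compound 3 (1.90 log units; beyond the scatter) and by a 3.2-fold higher number from compound 2 to compound 3 (0.50 log units; beyond the scatter), while a 25-fold higher number from compound 1 to compound 2 (1.40 log units; beyond the scatter) separates the other two. Compound 4 `C=Cc1ccnc(C#Cc2ccc3ncn(-c4ccnc(N)n4)c3c2)c1` is not yet measured. It differs from compound 3 by a group of 8 heavy atoms (7 carbon, 1 nitrogen; one six-membered aromatic ring with 1 hetero atom) in place of a group of 8 heavy atoms (7 carbon, 1 nitrogen; one six-membered aromatic ring with 1 hetero atom), on a triple-bonded carbon. Among the measured compounds shown here, no measured step bears directly on this change: both measured steps put a group in place of hydrogen on that carbon rather than rearranging the group already there, and they show only that what sits there moves this assay strongly. The step in this assay is therefore expected to be small, within or near the scatter: a 1.3-fold lower number from compound 3 to compound 4 (0.10 log units; within the scatter). Compound 4 is estimated at 16000 nM, with a range from 5000 nM to 50000 nM.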

Compound 4, half-maximal inhibitory concentration: 1580 nM
Beside the measured number, compound 4's estimate is 10-fold (1.01 log units) above it; the measured number lies below the stated range.
By their numbers in this assay, from the lowest: compound 1; then compound 4; then compound 2; then compound 3.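

In this assay the group on the triple-bonded carbon counts by how its atoms are joined, not only by which atoms it holds: exchanging 2-vinylpyridin-4-yl for its isomer gives a large step (a 13-fold lower number from compound 3 to compound 4 (1.10 log units; beyond the scatter)). The isomer also improves on ((vinylcarbonyl)amino)methyl (a 4.0-fold lower number from compound 2 to compound 4 (0.60 log units; beyond the scatter)), yet hydrogen still gives the lower number (a 6.3-fold higher number from compound 1 to compound 4 (0.80 log units; beyond the scatter)). Nothing at hand accounts for the gap between the isomers. Open, from the compounds shown here alone, is what an ethyl group or an amine in place of the vinyl group would do, and how a longer chain on that carbon would read.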